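Shortening the Acyl Group on a Shared Piperazine Amide

The source may hold more compounds than are shown below. What is called first, only, known or untested is meant among the compounds shown, and "the series" means these compounds.

Of the compounds shown here, three sharing one core have been tested in an ADME assay on Vero cells (Chlorocebus sabaeus) for cytotoxicity, read by MTT assay, with a stated time of 72 h; a higher number here means that more compound is tolerated, a lower number that less compound is tolerated. Compound 1 `Cc1ccc(C(=O)N2CCN(c3nc(=O)c4cc(C(F)(F)F)cc([N+](=O)[O-])c4s3)CC2)cc1` carries a 4-methylphenyl group on its amide carbonyl carbon, and in this assay compound 1 gives > 125000 nM, which is a limit of the assay rather than a number. Compound 2 `CCCCC(=O)N1CCN(c2nc(=O)c3cc(C(F)(F)F)cc([N+](=O)[O-])c3s2)CC1` has a butyl group in the same place, and compound 2 gives > 125000 nM, again a limit. Compound 3 `O=C(C1CCC1)N1CCN(c2nc(=O)c3cc(C(F)(F)F)cc([N+](=O)[O-])c3s2)CC1` carries a cyclobutyl group there, and compound 3 gives > 125000 nM, also a limit. Accordingly the steps a step that the two limits leave unreadable from compound 1 to compound 2, a step that the two limits leave unreadable from compound 1 to compound 3 and a step that the two limits leave unreadable from compound 2 to compound 3 cannot be sized, since (the limit of > 125000 nM in this assay, at which 3 of the 3 values shown sit).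

Compound 4 `CCC(=O)N1CCN(c2nc(=O)c3cc(C(F)(F)F)cc([N+](=O)[O-])c3s2)CC1` differs from compound 3 by ethyl in place of cyclobutyl on a carbonyl carbon. Every measured change at this carbonyl carbon, whether to an aryl, a chain or a small ring, has left the value at the same limit, so no step beyond the scatter is expected from compound 3 to compound 4. Compound 4 is therefore estimated at 125000 nM, within a range from 60000 nM to 250000 nM, an expected step of a number no higher from compound 3 to compound 4 (the limit leaves the size open).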

Compound 4, half-maximal cytotoxic concentration: > 125000 nM
Compound 4: a limit, no number; the forecaster's own chance of this, stated with the estimate: 85%; the middle value lies on the limit itself.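

For the compounds shown here, compound 4 also sits at a limit, so no step linking it to compound 1, compound 2 or compound 3 can be read, because all four share that limit: the limit of > 125000 nM in this assay, at which 4 of the 4 values shown sit. The compounds shown leave open whether any group on this carbonyl carbon changes the true value in this assay.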